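The source may report more compounds than this note shows. Statements on the series, on what has been measured and on what is new or still open speak of the compounds shown alone.

Compound 1 `CSc1ccc(NC(=O)Nc2cc(C)nc3ccccc23)cc1`: > 25000 nM
Compound 2 `Cc1cc(NC(=O)Nc2cccc(C(N)=O)c2)c2ccccc2n1`: > 25000 nM

Both entries come from an ADME assay on BJ cells (Homo sapiens) for cytotoxicity, with a stated time of 72 h; a higher number here means that more compound is needed for the effect, a lower number that less compound is needed. Compound 1 stands at > 25000 nM, which is a limit of the assay and not a number. Compound 2 stands at > 25000 nM, which is also a limit. Among the compounds with values here, the series so far therefore shows only (the limit of > 25000 nM in this assay, at which 2 of the 2 values shown sit).

Compound 3 `Cc1ccc(NC(=O)Nc2cc(C)nc3ccccc23)cc1` keeps the core of compound 1 and has methyl in place of methylsulfanyl on an aromatic carbon, para to a large group: methyl in place of methylsulfanyl on an aromatic carbon. Within the data shown here, no measured step between compounds is available for comparison, so the expectation rests on the limit shared by compound 1 and compound 2. No change beyond the scatter is expected in this assay, in either direction, and the expected step of a number no higher from compound 1 to compound 3 (the limit leaves the size open) reflects this. Compound 3 is most likely to sit at the same limit. As a number, compound 3 is estimated at 25000 nM, with an expected range of 12500 nM to 50000 nM.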

Compound 3, half-maximal effective concentration: > 25000 nM
Compound 3 ended at the assay's limit (the forecaster's own chance of this, stated with the estimate: 85%); the middle value sits exactly at the limit.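

Within the data shown here, compound 1 and compound 3 both stand at a limit of the assay in this assay, so no step between them can be read. The concentration at which any of these compounds would give a half-maximal effect in this assay remains open, with all values shown at one limit: the limit of > 25000 nM in this assay, at which 3 of the 3 values shown sit.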